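Three carbamates at the assay ceiling; an acetylated fourth awaits

The compounds below may be only part of what the source reports. "The series", "measured", "known", "first", "only" and "open" are said of these compounds alone.

Measured so far:
- compound 1 `CCC(COc1ccccc1)OC(=O)NCc1ccccc1`; in an assay for inhibition of zeta-carotene desaturase, chloroplastic/chromoplastic (Capsicum annuum), using a Dixon plot, with a stated time of 8 h (a lower number here means a stronger inhibitor, a higher number a weaker inhibitor), compound 1 gives > 100000 nM, a limit.
- compound 2 `CCC(COc1cccc(Cl)c1)OC(=O)NCc1ccccc1`; in this assay compound 2 gives > 100000 nM, a limit.
- compound 3 `CCC(COc1c(Cl)cccc1Cl)OC(=O)NCc1ccccc1`; in this assay compound 3 gives > 100000 nM, a limit.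

Compound 2 stands, like the other two, only at a limit; all three sit at the limit of > 100000 nM in this assay, at which 3 of the 3 values shown sit. The steps a step that the two limits leave unreadable from compound 1 to compound 2, a step that the two limits leave unreadable from compound 1 to compound 3 and a step that the two limits leave unreadable from compound 2 to compound 3 are therefore unreadable in size.

Compound 4 `CCC(COc1cccc(Cl)c1)OC(=O)N(Cc1ccccc1)C(C)=O` differs from compound 2 by acetyl in place of hydrogen on an amide-type nitrogen. No measured step touches this nitrogen, so nothing shown reads on the change, and the three limits give no footing for a direction. Compound 4 is expected to remain at or near the limit, an estimated step that the limit leaves unreadable from compound 2 to compound 4. The estimate for compound 4 in this assay is 150000 nM, within 30000 nM to 1000000 nM.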

Compound 4, half-maximal inhibitory concentration: > 100000 nM
Compound 4: a limit, no number; the forecaster's own chance of this, stated with the estimate: 80%; the middle value lies beyond the limit too.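

Compound 2 and compound 4 both stand at a limit, so the step between them cannot be read in size: the limit of > 100000 nM in this assay, at which 4 of the 4 values shown sit.

The compounds shown leave open whether any change to the shared core would give a number rather than a limit.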